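Cytotoxicity notes on amide tail variants

The source may hold more compounds than are shown below. What is called first, only, known or untested is meant among the compounds shown, and "the series" means these compounds.

Compound 1, `Cc1cc(C#N)cc(C)c1Oc1nc(Nc2ccc(C#N)cc2)ncc1/C=C/C(=O)NC1CCN(S(C)(=O)=O)C1`: > 179 nM
Compound 2, `Cc1cc(C#N)cc(C)c1Oc1nc(Nc2ccc(C#N)cc2)ncc1/C=C/C(=O)NCC1CCN(S(C)(=O)=O)C1`: > 175 nM

In an ADME assay on TZM cells (Homo sapiens) for cytotoxicity, with a stated time of 1 days (a lower number here means that less compound is tolerated, a higher number that more compound is tolerated), compound 1 reaches only a limit, > 179 nM. Compound 2 likewise gives only a limit, > 175 nM. The step that the two limits leave unreadable from compound 1 to compound 2 cannot be sized, as both values rest at their limits (the limit of > 175 nM in this assay, at which 1 of the 2 values shown sits, (the limit of > 179 nM in this assay, at which 1 of the 2 values shown sits)). Compound 2 thus stands at a limit and not at a number, so nothing separates it from compound 1 on what is shown.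

Compound 3, `Cc1cc(C#N)cc(C)c1Oc1nc(Nc2ccc(C#N)cc2)ncc1/C=C/C(=O)NCCN1CCN(S(C)(=O)=O)CC1`, carries (4-(methylsulfonyl)piperazin-1-yl)methyl in place of 1-(methylsulfonyl)pyrrolidin-3-yl on a saturated chain carbon bound to an amide-type nitrogen. For the measured compounds named here, the only measured step that bears on this tail, from compound 1 to compound 2, is unreadable, so no direction can be drawn from it. With both neighbours at limits, compound 3 is expected to show no step beyond the scatter in this assay, a step that the limit leaves unreadable from compound 2 to compound 3. Compound 3 is estimated at 180 nM, within 100 nM to 400 nM, and is expected most likely to be reported again as a limit.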

Compound 3, half-maximal cytotoxic concentration: > 166 nM
Compound 3: no number, only a limit; the forecaster's own chance of this, stated with the estimate: 80%; the middle value lies beyond the limit too.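

In this assay compound 3 gives only a limit, > 166 nM. For the compounds shown here, no step among compound 1, compound 2 and compound 3 can be read, as all three values are limits. The compounds shown leave open where the half-maximal cytotoxic concentration of each amide tail variant lies.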